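A few compounds are considered here, and "the series" means these few. Any claim that something is new, unique, unknown or untested is made for them only; others in the source may bear on it.

Of the compounds shown here, three sharing one core have been tested in a functional assay on WI-38 VA13 cells (Homo sapiens) for cytotoxicity; on this read-out higher numbers stand for an effect only at larger amounts of compound and lower numbers for an effect already at smaller amounts. Compound 1 `O=C(Nc1ccc2nc(NC(=O)C3CCCCC3)sc2c1)c1cccc(F)c1` gives 0.64 ug/mL in this assay, and compound 2 `CC(=O)Nc1ccc2nc(NC(=O)C3CCCCC3)sc2c1` gives 2.7 ug/mL. Among the measured compounds shown here, the single measured step between two compounds that differ in one place is a 4.2-fold higher number from compound 1 to compound 2 (0.63 log units; beyond the scatter), a methyl in place of a 3-fluorophenyl on a carbonyl carbon. Compound 3 `COC(=O)Nc1nc2ccc(NC(=O)c3c(Cl)cccc3Cl)cc2s1` gives 0.0095 ug/mL, the lowest of the three numbers; compound 1 stands nearest to it and compound 2 furthest, and both gaps lie beyond the scatter.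

Compound 4 `CCCCCCNC(=O)Nc1nc2ccc(NC(=O)c3c(Cl)cccc3Cl)cc2s1` differs from compound 3 by a single change, (hexylamino in place of methoxy on a carbonyl carbon). The only measured step, from compound 1 to compound 2, concerns a carbonyl carbon whose neighbours differ from the one changed here, and the exchange of methoxycarbonyl for hexylcarbamoyl has no measured counterpart among these compounds. That one step was modest, so the most that can reasonably be expected is a step of similar or smaller size in either direction, or none beyond the scatter. The estimate for compound 4 is 0.015 ug/mL, with a range from 0.003 ug/mL to 0.08 ug/mL. This estimate corresponds to an expected step of a 1.6-fold higher number from compound 3 to compound 4 (0.20 log units; within the scatter).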

Compound 4, half-maximal effective concentration: 0.29 ug/mL
Compound 4: the middle estimate sits 19-fold (1.29 log units) below what was measured; measured number outside the range, above it.
By their numbers in this assay, from the lowest: compound 3; then compound 4; then compound 1; then compound 2.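

In this assay, the carbonyl carbon bearing the amide-type nitrogen proves to be a sensitive place, as hexylamino in place of methoxy gives a 31-fold higher number from compound 3 to compound 4 (1.48 log units; beyond the scatter) and so a large step. Among the compounds shown here, the only earlier step, a 4.2-fold higher number from compound 1 to compound 2 (0.63 log units; beyond the scatter) and modest in size, involved a different group on a different carbonyl carbon, so it gave no sign that a change at this place could be so large. Nothing available accounts for the size of this step, in which methoxy, with 2 heavy atoms and no hydrogen-bond donor, gives way to hexylamino, with 7 heavy atoms and 1 hydrogen-bond donor.

The compounds shown do not separate the exchange of oxygen for nitrogen from the addition of the longer chain: methylamino on this carbonyl carbon would carry the nitrogen with a short chain, while hexyloxy would carry the long chain with the oxygen kept. As far as these compounds go, it also remains open whether a chain of intermediate length, such as propylamino, would give a step of intermediate size.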